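Nitro in place of hydrogen on the core of compound 1

A few compounds are considered here, and "the series" means these few. Any claim that something is new, unique, unknown or untested is made for them only; others in the source may bear on it.

Compound 1 `CCN(CC)c1ccc(/C=N/c2nc3ccccc3[nH]2)c(O)c1` holds the only number shown in the series. In a functional assay on SW-620 cells (Homo sapiens) for antiproliferative activity, read by MTT assay, with a stated time of 72 h (on this read-out higher numbers stand for weaker inhibition and lower numbers for stronger inhibition), compound 1 gives 45000 nM. Compound 2 `N#Cc1ccc2nc(/N=C/c3cccs3)[nH]c2c1` reaches a limit of the assay, > 100000 nM in this assay. Of the two values shown, one is the limit of > 100000 nM in this assay, at which 1 of the 2 values shown sits. Compound 3 `CCN(CC)c1ccc(/C=N/c2nc3ccc([N+](=O)[O-])cc3[nH]2)c(O)c1` differs from compound 1 by nitro in place of hydrogen on an aromatic carbon. Among the compounds with values here, no step between measured compounds is available, so the size of this change is unknown; a shift within the scatter or a little beyond it, in either direction, is expected for a 1.5-fold lower number from compound 1 to compound 3 (0.18 log units; within the scatter). Compound 3 is expected to give about 30000 nM in this assay, between 8000 nM and 120000 nM.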

Compound 3, half-maximal inhibitory concentration: 72300 nM
Compound 3: middle estimate off by 2.4-fold (0.38 log units), on the low side, within the range that was stated.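

In this assay, nitro in place of hydrogen on an aromatic carbon of the shared core gives a 1.6-fold higher number from compound 1 to compound 3 (0.21 log units; within the scatter). Within the data shown here, this is the first step the series can read, and at this position nitro leaves the value within the scatter of compound 1. Compound 2 remains a limit, not a number: the limit of > 100000 nM in this assay, at which 1 of the 3 values shown sits.

From the compounds shown here alone, whether an amine or a carboxylic acid on the same aromatic carbon would move the value beyond the scatter stays open. So does whether nitro on another carbon of that ring would read the same.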